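The source may report more compounds than this note shows. Statements on the series, on what has been measured and on what is new or still open speak of the compounds shown alone.

Measured compounds in hand:
- compound 1 `CCCN(CCC)CCCCOc1ccccc1/C=C/c1ccccc1`: 0%
- compound 2 `OC1CCN(CCCCOc2ccccc2/C=C/c2ccccc2)CC1`: 0%

In a functional assay on the whole organism with Mus musculus as the target, in the maximal electroshock model, at a dose of 50 mg/kg by the oral route (on this read-out lower numbers stand for less inhibition and higher numbers for more inhibition at the one dose given (going by the name of the read-out)), compound 1 gives 0%. Compound 2 gives 0% in the same assay, so compound 2 stands level with compound 1 at the digits printed, with no change within the scatter. For the measured compounds named here, the one measured step, no change at the digits printed from compound 1 to compound 2 (within the scatter), is the only comparison available, and it swaps the amine end of the chain without any movement in the read-out.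

Compound 3 `CCCN1CCN(CCCCOc2ccccc2/C=C/c2ccccc2)CC1` is the next member and is not yet measured. It differs from compound 2 by 4-propylpiperazin-1-yl in place of 4-hydroxypiperidin-1-yl on a saturated chain carbon, four bonds along the chain from an oxygen on an aromatic ring. This is again a swap at the amine end of the chain, the same place that was altered in the measured step, and that step was flat. Going by the values given here, no measured compound in this small set shows any inhibition, and nothing here points to the new amine behaving otherwise.

The expected step from compound 2 to compound 3 is therefore none beyond the scatter, a number 5 percentage points higher from compound 2 to compound 3 (within the scatter). For compound 3 the estimate in this assay is 5%, with a range of 0% to 30%; an upward move cannot be ruled out on two data points, so the range is kept wide on the high side.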

Compound 3, a percentage reported as inhibition, in the whole organism at one dose (the size of the read-out at that dose, not a potency): 42.9%
Compound 3: the middle estimate sits 37.9 percentage points below what was measured; measured number above the stated range.
By their numbers in this assay, from the lowest: compounds 1 and 2 (each within the scatter of the next); then compound 3.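

On a saturated chain carbon, four bonds along the chain from an oxygen on an aromatic ring, this assay does respond to the amine group: 4-propylpiperazin-1-yl in place of 4-hydroxypiperidin-1-yl gives a number 42.9 percentage points higher from compound 2 to compound 3 (beyond the scatter) and, in place of dipropylamino, gives a number 42.9 percentage points higher from compound 1 to compound 3 (beyond the scatter). The flat step between the first two compounds therefore did not mean that this position is silent, since among the amine groups shown only 4-propylpiperazin-1-yl, with two hetero atoms in its six-membered ring, stands apart from the other two. No data at hand bear on why the read-out moves with this change.

Going by these compounds, whether the gain goes with the second ring nitrogen or with the propyl group on it remains open, and piperazin-1-yl or 4-methylpiperazin-1-yl on the same chain would separate the two. Also open is whether the effect of 4-propylpiperazin-1-yl holds with a shorter or longer chain between the aromatic oxygen and the amine, as all the compounds shown carry the same chain.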